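The source may report more compounds than this note shows. Statements on the series, on what has been measured and on what is new or still open speak of the compounds shown alone.

Of the compounds shown here, two of a shared core have been measured for how well they dissolve. Compound 1 `Cc1csc(C(=O)N[C@H]2CN(S(=O)(=O)c3ccccc3)C[C@@H]2C(=O)N[C@H]2CCCNC2)n1` gives, in a physicochemical assay for solubility, at pH 7.4 (on this read-out lower numbers stand for lower solubility and higher numbers for higher solubility), a reading of 847000 nM. Among the compounds with values here, compound 2 `O=C(N[C@H]1CN(S(=O)(=O)c2ccccc2)C[C@@H]1C(=O)N[C@H]1CCCNC1)c1nnc(-c2ccc(F)cc2)s1` gives in this assay a reading of 234000 nM, the lower of the two numbers, the only other compound being compound 1 with the higher one. Within the data shown here, the single measured step, a 3.6-fold lower number from compound 1 to compound 2 (0.56 log units; beyond the scatter), shows what happened when the smaller ring group on the carbonyl carbon was exchanged for a larger two-ring group.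

Compound 3 `O=C(N[C@H]1CN(S(=O)(=O)c2ccccc2)C[C@@H]1C(=O)N[C@H]1CCCNC1)c1cc(-c2ccccc2Cl)on1` differs from compound 2 in one place: a group of 12 heavy atoms (9 carbon, 1 nitrogen, 1 oxygen, 1 chlorine; one five-membered aromatic ring with 2 hetero atoms, one six-membered aromatic ring of carbon only) in place of a group of 12 heavy atoms (8 carbon, 2 nitrogen, 1 fluorine, 1 sulfur; one five-membered aromatic ring with 3 hetero atoms, one six-membered aromatic ring of carbon only), on a carbonyl carbon. This exchange keeps the two-ring arrangement and the same count of heavy atoms, so the step from compound 1 to compound 2 bears on it only loosely, as a sign that changes at this position can move the number beyond the scatter. Nothing measured shows what trading one five-membered ring and halogen for another does here. For compound 3 the expectation is a reading in this assay near 200000 nM, likely between 70000 nM and 500000 nM. The step from compound 2 to compound 3 is therefore estimated as a 1.2-fold lower number from compound 2 to compound 3 (0.07 log units; within the scatter), within the scatter.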

Compound 3, solubility: 12000 nM
Beside the measured number, compound 3's estimate is 17-fold (1.22 log units) above it; measured number outside the range, below it.
By their numbers in this assay, from the lowest: compound 3; then compound 2; then compound 1.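

The two-ring arrangement and the count of 12 heavy atoms stay the same in this exchange on the carbonyl carbon, yet this assay shows a 20-fold lower number from compound 2 to compound 3 (1.29 log units; beyond the scatter), a larger step than a 3.6-fold lower number from compound 1 to compound 2 (0.56 log units; beyond the scatter), which came with a real increase in group size. Size alone therefore does not set the number at this position, since which rings and which halogen make up a group of the same size can matter a great deal. Set against the smaller group, the new group gives a 71-fold lower number from compound 1 to compound 3 (1.85 log units; beyond the scatter), and no measurement at hand explains why the two groups of equal size part so widely.

The exchange alters the five-membered ring, its hetero atoms and the halogen all at once, so these compounds cannot show how much of the drop belongs to the ring and how much to fluorine giving way to chlorine. Also open, on these data alone, is whether a carboxylic acid or an amine carried on the six-membered ring of this group would raise the number again.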